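Ester in place of the chain end of compound 3

A few compounds are considered here, and "the series" means these few. Any claim that something is new, unique, unknown or untested is made for them only; others in the source may bear on it.

Of the compounds shown here, three sharing one core have been tested in an assay on isolated protein for inhibition of leukotriene B4 receptor 1 (Homo sapiens), tested at 10 uM; on this read-out lower numbers stand for less inhibition and higher numbers for more inhibition at the one concentration tested (going by the name of the read-out). Compound 1, `C=CCc1cc(C(C)=O)c(O)cc1OCCCCCCC#N`, gives 97%. Compound 2, `C=CCc1cc(C(C)=O)c(O)cc1OCCCCCCCCCCC#N`, gives 50%. Compound 3, `C=CCc1cc(C(C)=O)c(O)cc1OCCCCCCC`, gives 31%, the lowest of the three: it sits a number 19 percentage points lower from compound 2 to compound 3 (beyond the scatter) and a number 66 percentage points lower from compound 1 to compound 3 (beyond the scatter).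

Compound 4, `C=CCc1cc(C(C)=O)c(O)cc1OCCCCCC(=O)OC`, has not been measured in this assay. It differs from compound 3 as follows: methoxycarbonyl in place of ethyl on a saturated chain carbon, five bonds along the chain from an oxygen on an aromatic ring. So the plain chain end of compound 3 is exchanged for a group that carries two hydrogen-bond acceptors.

For the measured compounds named here, the steps that bear on this are those that replaced a nitrile at the chain end with a plain chain: a number 66 percentage points lower from compound 1 to compound 3 (beyond the scatter) and a number 19 percentage points lower from compound 2 to compound 3 (beyond the scatter). Both show that a chain ending in a plain carbon gives far less inhibition than one ending in a nitrile. An acceptor-bearing group at the chain end is therefore expected to raise the number, with a number 34 percentage points higher from compound 3 to compound 4 (beyond the scatter), though a methoxycarbonyl is not a nitrile and the chain here is shorter, so the step is uncertain. Compound 4 is estimated at 65%, within 35% to 90%.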

Compound 4, a percentage reported as inhibition, at one concentration (the size of the read-out at that concentration, not a potency): 106%
For compound 4 the middle estimate is 41 percentage points below the measured one; the measured number lies above the stated range.
By their numbers in this assay, from the lowest: compound 3; then compound 2; then compounds 1 and 4 (each within the scatter of the next).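

In this assay, the methoxycarbonyl chain end gives a large gain over the plain chain, a number 75 percentage points higher from compound 3 to compound 4 (beyond the scatter), which shows that a nitrile is not the only chain end to lift the number well above that of a plain chain. The ester chain end also clears the long nitrile chain, a number 56 percentage points higher from compound 2 to compound 4 (beyond the scatter), whereas the other nitrile chain gives a number 9 percentage points higher from compound 1 to compound 4 (within the scatter), so those two compounds cannot be told apart in this assay. No measurement here bears on why these chain ends differ.

Still open, from the compounds shown here alone, is which part of the ester matters. A carboxylic acid or a primary amide at the same chain end, or a methoxycarbonyl on a longer chain, would help separate the effect of the end group from that of chain length.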